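The source may hold more compounds than are shown below. What is called first, only, known or untested is meant among the compounds shown, and "the series" means these compounds.

Compound 1 `CN(C)c1ccc(/C=C2/SC(N(c3ccccc3)c3ccccc3)=NC2=O)cc1` is the starting point, and its activity is read in a functional assay on NCI-H460 cells (Homo sapiens) for cytotoxicity, read by sulforhodamine B assay, with a stated time of 48 h; on this read-out higher numbers stand for an effect only at larger amounts of compound and lower numbers for an effect already at smaller amounts. In this assay compound 1 gives > 100000 nM, which is a limit of the assay and not a number. Compound 2 `CCN(CC)c1ccc(/C=C2/SC(N(c3ccccc3)c3ccccc3)=NC2=O)cc1`, carrying diethylamino in place of dimethylamino on an aromatic carbon, gives > 100000 nM, also a limit. Compound 3 `CN1CCN(c2ccc(/C=C3/SC(N(c4ccccc4)c4ccccc4)=NC3=O)cc2)CC1`, carrying 4-methylpiperazin-1-yl on that aromatic carbon, gives > 100000 nM, again a limit. Because of the limit of > 100000 nM in this assay, at which 3 of the 3 values shown sit, the steps a step that the two limits leave unreadable from compound 1 to compound 2, a step that the two limits leave unreadable from compound 1 to compound 3 and a step that the two limits leave unreadable from compound 2 to compound 3 cannot be sized, so compound 1 stands on the same limit as the other two measured compounds and cannot be ranked against them.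

Compound 4 `CN(C)c1ccc(/C=C2/SC(N(C)c3ccccc3)=NC2=O)cc1` differs from compound 1 in methyl in place of phenyl on a nitrogen on an aromatic ring. None of the three measured steps touches this nitrogen; each of them alters only the group on the aromatic carbon, and each is unreadable. Going by the values given here, no measured step therefore bears on this change, and no direction can be drawn from them.

With every measured value sitting at the limit, compound 4 is expected to give about 100000 nM, with a range from 30000 nM to 300000 nM. The expected step is estimated as a number no higher from compound 1 to compound 4 (the limit leaves the size open), not a change beyond the scatter.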

Compound 4, half-maximal effective concentration: 80 nM
Compound 4: the middle estimate sits 1300-fold (3.10 log units) above what was measured; measured number below the stated range.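

Going by these compounds alone, the group on this nitrogen carries far more weight in this assay than the earlier compounds could reveal: methyl in place of phenyl on a nitrogen on an aromatic ring gives an at least 1200-fold lower number from compound 1 to compound 4 (3.09 log units; beyond the scatter). Within the data shown here, compound 4 keeps the dimethylamino group of compound 1, so this single swap on the nitrogen is the only structural difference behind the step, and it is the first change here that moves a compound off the limit. The printed step gives only a minimum size, and the true gap may be larger, because the value of compound 1 is a limit and not a number: the limit of > 100000 nM in this assay, at which 3 of the 4 values shown sit.

The compounds shown leave open whether methyl is the best group on this nitrogen, or whether a hydrogen, an ethyl group or a longer chain would give a similar number. On these data alone, the steps among compound 1, compound 2 and compound 3 cannot be read, so it also remains open whether diethylamino or 4-methylpiperazin-1-yl on the aromatic carbon would change the number once methyl sits on the nitrogen.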